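The compounds below may be only part of what the source reports. "The series", "measured", "known", "first", "only" and "open" are said of these compounds alone.

Values in a functional assay on B16-F10 cells (Mus musculus) for antiproliferative activity, read by MTT assay, with a stated time of 48 h (on this read-out lower numbers stand for stronger inhibition and higher numbers for weaker inhibition), for the series:
compound 1 (`O=C(/C=C/c1ccc(Cl)cc1)Nc1cc(-c2ccccc2)[nH]n1`) gives 1270 nM
compound 2 (`O=C(/C=C/c1ccc(Br)cc1)Nc1cc(-c2ccccc2)[nH]n1`) gives 1380 nM
compound 3 (`Cc1ccc(/C=C/C(=O)Nc2cc(-c3ccccc3)[nH]n2)cc1`) gives 1680 nM

Compound 2 cannot be separated from the other two, with a 1.1-fold higher number from compound 1 to compound 2 (0.04 log units; within the scatter) and a 1.2-fold higher number from compound 2 to compound 3 (0.09 log units; within the scatter) as its steps. The next compound is compound 4 (`Cc1ccc(-c2cc(NC(=O)/C=C/c3ccc(Br)cc3)n[nH]2)cc1`), and the change is methyl in place of hydrogen on an aromatic carbon as methyl in place of hydrogen on an aromatic carbon, phenyl to 4-methylphenyl. Going by the values given here, no measured step makes this change on that ring. The closest evidence is methyl replacing a halogen elsewhere in the molecule, with a 1.2-fold higher number from compound 2 to compound 3 (0.09 log units; within the scatter) and a 1.3-fold higher number from compound 1 to compound 3 (0.12 log units; within the scatter) as small steps. In this assay no step beyond the scatter is therefore expected, and the estimate is a 1.0-fold higher number from compound 2 to compound 4 (0.01 log units; within the scatter) as the expected step. Compound 4 is expected at 1400 nM with an estimated range of 700 nM to 2800 nM as its bounds.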

Compound 4, half-maximal inhibitory concentration: 1570 nM
For compound 4 the middle estimate is 1.1-fold (0.05 log units) below the measured one, within the range that was stated.
By their numbers in this assay, from the lowest: compounds 1, 2, 4 and 3 (each within the scatter of the next).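

In this assay phenyl to 4-methylphenyl gives a 1.1-fold higher number from compound 2 to compound 4 (0.06 log units; within the scatter) as the only step shown on this ring, since the earlier compounds differ only at the halogen or methyl site elsewhere in the molecule. Methyl in place of hydrogen on this aromatic carbon, para to a large group, thus stays within the scatter. No available measurement bears on the reason for this result. Still open, going by these compounds, is whether an amine, a carboxylic acid or a longer chain at this position would give a step beyond the scatter.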